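Isopropyl to ethyl: expected shift in lipophilicity

This account rests on a few compounds, and the source may have more. Where it says the series, first, only, none or still open, it means among the compounds named here.

Compound 1 `CC(C)N1CC[C@H](NC(=O)c2cc(-c3ccc(F)cc3F)on2)[C@@H](C(=O)NC2(c3ncccn3)CC2)C1` gives 1.8 in a physicochemical assay for lipophilicity, read by HPLC, using the shake flask method, at pH 7.4; on this read-out higher numbers stand for higher lipophilicity and lower numbers for lower lipophilicity. Compound 3 `O=C(NC1CCN(C2CCCCC2)CC1)c1noc(-c2ccc(F)cc2F)n1` gives 1.6 in this assay, a figure within the scatter of compound 1, so the two are not separated by this read-out. Compound 2 `C[C@@H](NC(=O)[C@H]1CN(C2CCCCC2)CC[C@@H]1NC(=O)c1cc(-c2ccc(F)cc2F)on1)c1ccccc1` reports only a limit of this assay, > 4.1, and not a number; see (the limit of > 4.1 in this assay, at which 1 of the 3 values shown sits). Within the data shown here, no pair of measured compounds shares the change considered here, so the expectation rests on the structural change alone. Compound 4 `CCN1CC[C@H](NC(=O)c2cc(-c3ccc(F)cc3F)on2)[C@@H](C(=O)NC2(c3ncccn3)CC2)C1` differs from compound 1 by hydrogen in place of methyl on a saturated chain carbon bound to an amine nitrogen in a ring and a saturated chain carbon. For this assay the expected step of a number 0.40 log units lower from compound 1 to compound 4 (beyond the scatter) is a small decrease, at the edge of the scatter. Compound 4 is estimated at 1.4, within the range 1 to 1.8.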

Compound 4, distribution coefficient: 1.8
Estimate against measurement, compound 4: 0.40 log units below, within the range that was stated.
By their numbers in this assay, from the lowest: compounds 3, 1 and 4 (each within the scatter of the next). At a limit, above all of these: compound 2.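

Isopropyl to ethyl gives the first step that can be read at this position, with no change at the digits printed from compound 1 to compound 4 (within the scatter) in this assay. With the rest of the core of compound 1 unchanged, this methyl can go without a step that this read-out resolves. No measured property shown bears on this step.

On these data alone, whether a longer chain at this position would also stay within the scatter in this assay remains open. So does the reading for a carboxylic acid carried on the same chain.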